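The compounds below may be only part of what the source reports. "The series", "measured", "known", "first", "only" and "open" are said of these compounds alone.

Compound 1 `ClCc1ccccc1Cn1cnc2c(Cl)nc(Cl)nc21` has no result in a functional assay on COLO 205 cells (Homo sapiens) for cytotoxicity, read by sulforhodamine B assay, with a stated time of 48 h (a higher number here means a weaker inhibitor of growth, a lower number a stronger inhibitor of growth), its entry there reading "not determined" (no result reported). Compound 2 `Nc1nc(Cl)c2ncn(Cc3ccc(CCl)cc3)c2n1` gives 3630 nM in this assay.

Compound 1 therefore stands nowhere on the numbers: nothing was reported for it. Compound 3 `Nc1nc(Cl)c2ncn(Cc3ccccc3CCl)c2n1` arises from compound 1 by one change, (amino in place of chloro on an aromatic carbon), that is, amino in place of chloro on an aromatic carbon. Going by the values given here, no measured pair shows this change, so its size and direction in this assay are unknown; a step beyond the scatter cannot be excluded. Compound 3 is expected to reach about 3500 nM in this assay, between 900 nM and 14000 nM, because compound 2 carries the same amino group and gives 3630 nM.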

Compound 3, concentration for 50% growth inhibition: 5010 nM
Compound 3: middle estimate off by 1.4-fold (0.16 log units), on the low side; the measured number falls inside the stated range.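

In this assay, going by these compounds alone, compound 1 reads "not determined" (no result reported), so no step to compound 3 can be read. From the compounds shown here alone, the size and direction of amino in place of chloro on an aromatic carbon stay open. Nothing available explains the value of compound 3.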